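Swapping Chlorine for Bromine on a Coumarin Ester

The source may hold more compounds than are shown below. What is called first, only, known or untested is meant among the compounds shown, and "the series" means these compounds.

Of the compounds shown here, three have been measured so far. Compound 1 `CC(=O)OCc1ccc2oc(=O)c(C(=O)Sc3cccc(Cl)c3)cc2c1` and compound 2 `CC(=O)OCc1ccc2oc(=O)c(C(=O)Sc3cccc(Br)c3)cc2c1` share one core, and compound 3 `CC(=O)NCc1ccc2oc(=O)c(C(=O)Oc3cccc(Cl)c3)cc2c1` has a different one; how the two cores differ is not broken down here. In a functional assay on HT-1080 cells (Homo sapiens), read by transwell migration, with a stated time of 24 h, tested at 1 uM (on this read-out lower numbers stand for a stronger effect and higher numbers for a weaker effect at the one concentration tested), compound 1 gives 65.8% and compound 2 gives 70.9%. The step of a number 5.1 percentage points higher from compound 1 to compound 2 (within the scatter) comes from a single change, (bromo in place of chloro on an aromatic carbon), and it lies within the scatter, so the two numbers cannot be told apart. In this assay compound 3 gives 36.6%. This is the lowest of the three numbers, and its gaps to compound 1 and to compound 2 both lie beyond the scatter, so compound 3 shows the strongest effect among the measured compounds.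

Compound 4 `CC(=O)NCc1ccc2oc(=O)c(C(=O)Oc3cccc(Br)c3)cc2c1` has not yet been measured. It arises from compound 3 by bromo in place of chloro on an aromatic carbon, which is the same change that turns compound 1 into compound 2, made at the same kind of place on the ring. Since that earlier change gave only a number 5.1 percentage points higher from compound 1 to compound 2 (within the scatter), the step of a number 3.4 percentage points higher from compound 3 to compound 4 (within the scatter) is expected to be of a similar small size, well inside the scatter. Compound 4 is therefore expected to give about 40% in this assay, most likely between 27% and 55%.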

Compound 4, a percentage reported as activity, at one concentration (the size of the read-out at that concentration, not a potency): 36.9%
Estimate against measurement, compound 4: 3.1 percentage points above; the measured number falls inside the stated range.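

In this assay, putting bromo in place of chloro on the aromatic ring gives a number 0.3 percentage points higher from compound 3 to compound 4 (within the scatter), so on this core too the two halogens cannot be told apart. The change therefore behaves alike on both cores, with a step too small to read each time, and the two steps themselves do not differ: the same change on two cores in this assay, a number 5.1 percentage points higher (within the scatter) from compound 1 to compound 2 and a number 0.3 percentage points higher (within the scatter) from compound 3 to compound 4, 4.8 percentage points apart, within the scatter of two such steps This shows that in this one assay, at the one concentration tested, the swap leaves the read-out within its usual scatter on both cores, but two pairs of compounds make no rule for other cores, and a step this small does not prove that the swap has no effect at all.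

The compounds shown carry only chloro or bromo at this place on the ring, so it stays open whether another group there, such as a methoxy group, a nitrile or an amine, would move the number beyond the scatter. The two cores also differ in more than one place, and with no compound that changes just one of those places, the pairs shown cannot say which of them matters for this read-out.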